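The source may hold more compounds than are shown below. What is called first, only, known or untested is meant among the compounds shown, and "the series" means these compounds.

Measured compounds in an assay on isolated protein for displacement of a labelled ligand from secreted frizzled-related protein 1 (Homo sapiens), read by fluorescence polarization, with a stated time of 30 min; on this read-out lower numbers stand for stronger inhibition and higher numbers for weaker inhibition:
- compound 1 `CN(C)c1ccc(C(=O)N2CCC(NS(=O)(=O)c3cc(S(=O)(=O)c4ccccc4)ccc3C(F)(F)F)CC2)cc1`: 300 nM
- compound 2 `O=C(c1cccnc1)N1CCC(NS(=O)(=O)c2cc(S(=O)(=O)c3ccccc3)ccc2C(F)(F)F)CC1`: 80 nM
- compound 3 `CN(C)c1ccc(C(=O)N2CCC(NS(=O)(=O)c3cc(S(=O)(=O)c4ccccc4)ccc3C(F)(F)F)CC2)cn1`: 40 nM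

Compound 3 holds the lowest number of the three; compound 2 sits close (a 2.0-fold lower number from compound 2 to compound 3 (0.30 log units; within the scatter)), compound 1 further away (a 7.5-fold lower number from compound 1 to compound 3 (0.88 log units; beyond the scatter)). Compound 4 `O=C(O)c1ccc(S(=O)(=O)N2CCC(NS(=O)(=O)c3cc(S(=O)(=O)c4ccccc4)ccc3C(F)(F)F)CC2)cc1` differs from compound 3 by (4-carboxyphenyl)sulfonyl in place of (6-(dimethylamino)pyridin-3-yl)carbonyl on an amine nitrogen in a ring. Every measured step varied only the aryl group on the carbonyl (a 3.8-fold lower number from compound 1 to compound 2 (0.57 log units; beyond the scatter), a 7.5-fold lower number from compound 1 to compound 3 (0.88 log units; beyond the scatter), a 2.0-fold lower number from compound 2 to compound 3 (0.30 log units; within the scatter)), all modest. Among the compounds with values here, no measured step touches the carbonyl-to-sulfonyl exchange or a carboxylic acid, so these steps bear on the change only loosely. A modest move toward higher numbers is therefore expected, a 3.8-fold higher number from compound 3 to compound 4 (0.57 log units; beyond the scatter), with wide uncertainty. Compound 4 is estimated at 150 nM, range 40 nM to 600 nM.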

Compound 4, half-maximal inhibitory concentration: 20 nM
For compound 4 the middle estimate is 7.5-fold (0.88 log units) above the measured one; the whole stated range lies above it.
By their numbers in this assay, from the lowest: compounds 4, 3 and 2 (each within the scatter of the next, the first and the last beyond it); then compound 1.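

In this assay the amine nitrogen in the ring accepts (4-carboxyphenyl)sulfonyl with no loss against the best carbonyl compound (a 2.0-fold lower number from compound 3 to compound 4 (0.30 log units; within the scatter)) and with real gains against the other two (a 4.0-fold lower number from compound 2 to compound 4 (0.60 log units; beyond the scatter); a 15-fold lower number from compound 1 to compound 4 (1.18 log units; beyond the scatter)). A sulfonyl link carrying a carboxylic acid is therefore tolerated at this position, which the carbonyl compounds could not show. Nothing at hand explains this result.

Sulfonyl link and aryl group changed together, so their separate contributions remain open. From the compounds shown here alone, whether a methyl ester or a primary amide can replace the carboxylic acid also remains open.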